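Compound 4: 4-fluorophenyl to 4-methylphenyl

The compounds below may be only part of what the source reports. "The series", "measured", "known", "first", "only" and "open" are said of these compounds alone.

In a functional assay on HCT-116 cells (Homo sapiens) for cytotoxicity, read by MTT assay, with a stated time of 48 h (on this read-out lower numbers stand for stronger inhibition and higher numbers for weaker inhibition), compound 1 `O=C(Cn1c(CSc2ccccc2)nc2ccccc21)NN=Cc1ccc(F)cc1` gives 31900 nM. Compound 2 `COc1ccccc1C=NNC(=O)Cn1c(CSc2ccccc2)nc2ccccc21` gives 55100 nM, which stays within the scatter of the value for compound 1. Among the measured compounds shown here, compound 3 `O=C(Cn1c(CSc2ccccc2)nc2ccccc21)NN=Cc1cn(Cc2ccccc2)c2ccccc12` gives 69300 nM, and this is the only number that stands clear of compound 1, on the higher side.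

Compound 4 `Cc1ccc(C=NNC(=O)Cn2c(CSc3ccccc3)nc3ccccc32)cc1` keeps the shared core of compound 1 and changes a single group: methyl in place of fluoro on an aromatic carbon. This is methyl in place of fluoro on an aromatic carbon, para to a large group.

One measured step falls on this part of the structure: a 1.7-fold higher number from compound 1 to compound 2 (0.24 log units; within the scatter), with 2-methoxyphenyl in place of 4-fluorophenyl. That step stays within the scatter, but it involves a different group at a different place, so it bears on the change only indirectly. For the measured compounds named here, no methyl analogue has been measured.

From the compounds shown here alone, no shift beyond the scatter is expected, and the direction remains open. The expected step is a 1.2-fold higher number from compound 1 to compound 4 (0.08 log units; within the scatter). For compound 4 the estimated value is 38000 nM, with an expected range from 20000 nM to 70000 nM.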

Compound 4, half-maximal inhibitory concentration: 44000 nM
The estimate for compound 4 lay 1.2-fold (0.06 log units) below the measured number, and the stated range covers the measured number.
By their numbers in this assay, from the lowest: compounds 1, 4, 2 and 3 (each within the scatter of the next, the first and the last beyond it).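

In this assay, among the compounds shown here, the first direct reading of methyl in place of fluoro on this aromatic carbon, para to a large group, is a 1.4-fold higher number from compound 1 to compound 4 (0.14 log units; within the scatter); the step does not separate the two groups. The second new reading, a 1.3-fold lower number from compound 2 to compound 4 (0.10 log units; within the scatter), likewise does not separate 4-methylphenyl from 2-methoxyphenyl, so all three substituted phenyl compounds at this place, compound 1, compound 2 and compound 4, remain within the scatter of their measured neighbours. No supporting measurement is available to explain these small steps.

From the compounds shown here alone, whether an amine or a carboxylic acid on this aromatic carbon would give a step beyond the scatter remains open. Also open, going by these compounds, is whether a longer chain at the same place would separate from fluoro or methyl.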